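The compounds below may be only part of what the source reports. "The series", "measured", "known", "first", "only" and "open" are said of these compounds alone.

Working notes on the series. Compound 1 `CCOC(=O)c1cc(-c2cccc(OCc3cccc(N)c3)c2)on1` carries the shared core. In an ADME assay on Vero cells (Chlorocebus sabaeus) for cytotoxicity, with a stated time of 72 h (a higher number here means a weaker inhibitor, a lower number a stronger inhibitor), compound 1 gives only a limit of the assay, > 128000 nM. Compound 2 `CCOC(=O)c1cc(-c2cccc(OCc3ccccc3F)c2)on1` differs from compound 1 at the outer six-membered aromatic ring of carbon only, where it carries the 2-fluorophenyl group. In this assay, among the measured compounds shown here, compound 2 gives "not determined" (no result reported), so no single number stands for compound 2; the only value shown in this assay across the two measured compounds is the limit of > 128000 nM in this assay, at which 1 of the 2 values shown sits, and that belongs to compound 1 alone. Compound 2 therefore has no measured footing of its own here.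

Compound 3 `CCOC(=O)c1cc(-c2cccc(OCc3ccc(F)cc3F)c2)on1` is still to be measured. It differs from compound 2 by fluoro in place of hydrogen on an aromatic carbon, the change reading as 2-fluorophenyl to 2,4-difluorophenyl. For the measured compounds named here, no step between measured compounds is available for this change. Given that the one recorded value in this assay is a limit, for the step from compound 2 to compound 3 no shift beyond the usual scatter is expected in this assay, and a limit rather than a number seems the likely outcome. Compound 3 is estimated at 150000 nM, with a range of 60000 nM to 400000 nM.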

Compound 3, half-maximal inhibitory concentration: > 128000 nM
Compound 3: only a limit was reported; the forecaster's own chance of this, stated with the estimate: 80%; the middle value does not contradict the limit.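

Compound 1 and compound 3 each give only a limit in this assay and compound 2 has no number, so no new step can be read among them: the limit of > 128000 nM in this assay, at which 2 of the 3 values shown sit.

The compounds shown leave open whether the 2,4-difluorophenyl, 2-fluorophenyl and 3-aminophenyl groups differ at all in this assay.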